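A few compounds are considered here, and "the series" means these few. Any claim that something is new, unique, unknown or untested is made for them only; others in the source may bear on it.

Compound 1 `CCCC(C)C(=O)Nc1c(C(O)(C(F)(F)F)C(F)(F)F)ccc2ccccc12`
Compound 2 `O=C(Nc1c(C(O)(C(F)(F)F)C(F)(F)F)ccc2ccccc12)c1ccccc1Cl`: 2040 nM
Compound 3 `COc1cccc(C(=O)Nc2c(C(O)(C(F)(F)F)C(F)(F)F)ccc3ccccc23)c1`: 185 nM

In an assay on LtK cells with ATP-sensitive inward rectifier potassium channel 11 (Homo sapiens) as the target (a higher number here means that more compound is needed for the effect, a lower number that less compound is needed), compound 1 gives only a limit, > 10000 nM. Among the two numbers, compound 2 stands highest, and the step of an 11-fold lower number from compound 2 to compound 3 (1.04 log units; beyond the scatter) separates it from its nearest neighbour. Compound 4 `O=C(Nc1c(C(O)(C(F)(F)F)C(F)(F)F)ccc2ccccc12)c1cc(Cl)cc(Cl)c1` differs from compound 2 by 3,5-dichlorophenyl in place of 2-chlorophenyl on a carbonyl carbon. The steps of an at least 4.9-fold lower number from compound 1 to compound 2 (0.69 log units; beyond the scatter) and an at least 54-fold lower number from compound 1 to compound 3 (1.73 log units; beyond the scatter) show that the group on the carbonyl carbon governs the number, and an 11-fold lower number from compound 2 to compound 3 (1.04 log units; beyond the scatter) shows that exchanging one aryl group for another can give a large step. Among the compounds with values here, no measured pair swaps one chlorophenyl for another, so the direction rests on those steps alone. A modest lowering is expected, a 2.9-fold lower number from compound 2 to compound 4 (0.46 log units; beyond the scatter). Compound 4 is therefore estimated at 700 nM, within a range from 200 nM to 2500 nM.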

Compound 4, half-maximal effective concentration: 306 nM
Beside the measured number, compound 4's estimate is 2.3-fold (0.36 log units) above it; measured number inside the range.
By their numbers in this assay, from the lowest: compounds 3 and 4 (each within the scatter of the next); then compound 2. At a limit, above all of these: compound 1.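

In this assay, the step of a 6.7-fold lower number from compound 2 to compound 4 (0.82 log units; beyond the scatter) shows that two chlorophenyl groups on the carbonyl carbon can give clearly different numbers, so the result for 2-chlorophenyl does not hold for every chlorinated phenyl group. With a 1.7-fold higher number from compound 3 to compound 4 (0.22 log units; within the scatter), 3,5-dichlorophenyl and 3-methoxyphenyl cannot be told apart here, although their substituents differ. The remaining step, an at least 32-fold lower number from compound 1 to compound 4 (1.51 log units; beyond the scatter), starts from a limit and not from a number: the limit of > 10000 nM in this assay, at which 1 of the 4 values shown sits.

Still open, from the compounds shown here alone, is how an amine, a nitrile or a carboxylic acid on the phenyl group would read. Also open, going by these compounds, is whether a longer chain in place of 1-methylbutyl would stay at a limit.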